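This account rests on a few compounds, and the source may have more. Where it says the series, first, only, none or still open, it means among the compounds named here.

Measured compounds in a functional assay on KB cells (Homo sapiens) for cytotoxicity; on this read-out lower numbers stand for stronger inhibition and higher numbers for weaker inhibition:

Compound 1 `COCCOCn1cc(C(N)=O)c2c(N)ncnc21` reaches only the limit of the assay, > 100000 nM.

Compound 2 `Cc1ccc(Cn2cc(C(N)=O)c3c(N)ncnc32)cc1` likewise gives only the limit > 100000 nM.

Compound 3 `C=CCn1cc(C#N)c2c(N)ncnc21` also gives only the limit > 100000 nM.

Compound 3 thus stands at the limit of this assay, as do all three values shown (the limit of > 100000 nM in this assay, at which 3 of the 3 values shown sit). Compound 4 `C=CCn1cc(C(N)=O)c2c(N)ncnc21` differs from compound 3 by carbamoyl in place of cyano on an aromatic carbon. Among the compounds with values here, the single measured step, a step that the two limits leave unreadable from compound 1 to compound 2, concerns a different part of the core and is unreadable between two limits, so no measured step bears on this change. Compound 1 and compound 2 already carry the carbamoyl group that enters, and both sit at the limit. No step beyond the usual scatter is expected from compound 3 to compound 4 in this assay, the expected step being a number no higher from compound 3 to compound 4 (the limit leaves the size open). Compound 4 is therefore estimated at 100000 nM, ranging from 40000 nM to 300000 nM, most likely again only a limit.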

Compound 4, half-maximal inhibitory concentration: 100000 nM
For compound 4 middle estimate and measured number coincide at the digits printed, within the range that was stated.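

In this assay compound 4 gives 100000 nM, the only actual number among the compounds shown. Compound 3 gives > 100000 nM, and this is a limit of the assay. Carbamoyl in place of cyano gives a number no higher from compound 3 to compound 4 (the limit leaves the size open). Vinyl in place of 4-methylphenyl gives a number no higher from compound 2 to compound 4 (the limit leaves the size open). Vinyl in place of 2-methoxyethoxy gives a number no higher from compound 1 to compound 4 (the limit leaves the size open). All three steps start from a limit, so their size cannot be read, and nearly all the values shown remain limits: the limit of > 100000 nM in this assay, at which 3 of the 4 values shown sit.

From the compounds shown here alone, it remains open whether any group on this aromatic carbon, such as a carboxylic acid or an amine, would give a clearly lower number. The same holds for a longer chain in place of the allyl group.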